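Notes on Compound 4: Relocating the Chlorine

The source may hold more compounds than are shown below. What is called first, only, known or untested is meant among the compounds shown, and "the series" means these compounds.

Measured so far in an assay on microsomes from brain for inhibition of Fatty-acid amide hydrolase 1 (Rattus norvegicus), read by fluorescence and HPLC, with a stated time of 60 min; a lower number here means a stronger inhibitor, a higher number a weaker inhibitor:
- compound 1 `CCCCCCCCc1ccc(OCC(=O)Cn2nnnc2C)cc1`: 41 nM
- compound 2 `CCCCCCCCc1ccc(OCC(=O)Cn2nnnc2-c2ccccc2)cc1`: 71 nM
- compound 3 `CCCCCCCCc1ccc(OCC(=O)Cn2nnnc2-c2cccc(Cl)c2)cc1`: 360 nM

Compound 3 gives the highest number of the three in this assay. Its nearest neighbour is compound 2, and the gap is a 5.1-fold higher number from compound 2 to compound 3 (0.71 log units; beyond the scatter), beyond the scatter. The wider gap is an 8.8-fold higher number from compound 1 to compound 3 (0.94 log units; beyond the scatter), also beyond the scatter. Between compound 1 and compound 2 the step is a 1.7-fold higher number from compound 1 to compound 2 (0.24 log units; within the scatter), which is within the scatter.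

Compound 4 `CCCCCCCCc1ccc(OCC(=O)Cn2nnnc2-c2ccccc2Cl)cc1` has the same atoms as compound 3, joined differently: 2-chlorophenyl in place of 3-chlorophenyl on an aromatic carbon. Among the compounds with values here, no measured step moves the chlorine around the phenyl ring, so the only steps that bear on it are those that add the 3-chlorophenyl or its chloro at all: a 5.1-fold higher number from compound 2 to compound 3 (0.71 log units; beyond the scatter) and an 8.8-fold higher number from compound 1 to compound 3 (0.94 log units; beyond the scatter). These show that a chlorine on the phenyl ring can shift the number well beyond the scatter, but say nothing about whether a 2-chlorophenyl does the same. The expectation is therefore a step of uncertain size, most likely a modest drop or none beyond the scatter, with a wide range on either side.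

Compound 4 is estimated at 250 nM (60 nM to 1000 nM), an expected step of a 1.4-fold lower number from compound 3 to compound 4 (0.16 log units; within the scatter) from compound 3.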

Compound 4, half-maximal inhibitory concentration: 4600 nM
Compound 4: the middle estimate sits 18-fold (1.26 log units) below what was measured, outside the stated range (above it).
By their numbers in this assay, from the lowest: compounds 1 and 2 (each within the scatter of the next); then compound 3; then compound 4.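

Moving the chlorine alone, with the same atoms on the same phenyl group, produces a 13-fold higher number from compound 3 to compound 4 (1.11 log units; beyond the scatter) in this assay, so the place of the chlorine matters at least as much here as its presence. Within the data shown here, both chlorinated compounds carry higher numbers than the unsubstituted phenyl of compound 2, but the 2-chlorophenyl gives a 65-fold higher number from compound 2 to compound 4 (1.81 log units; beyond the scatter) against a 5.1-fold higher number from compound 2 to compound 3 (0.71 log units; beyond the scatter) for the 3-chlorophenyl, and the same group in place of methyl gives a 110-fold higher number from compound 1 to compound 4 (2.05 log units; beyond the scatter) as the widest step so far. Nothing available accounts for the difference between the two chlorine placements.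

As far as these compounds go, it remains open whether the high number of compound 4 belongs to chlorine itself or would follow any group at that place, which fluoro, methyl or methoxy in place of its chlorine would begin to separate. Also open, from the compounds shown here alone, is how the number responds when the phenyl group carries an amine or a carboxylic acid instead of a chlorine, since every substituent on that ring so far is a single chloro.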